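The compounds below may be only part of what the source reports. "The series", "measured", "known", "first", "only" and "open" are said of these compounds alone.

Compound 2 `CCCCNC(=O)CC1CCc2cc(OC)c(OC)cc21` gives 24.1% in a functional assay on the whole organism (strain Wistar) for inhibition, with Rattus norvegicus as the target, read by paw edema, with stated times of 60 min and 6 h, at a dose of 100 mg/kg by the oral route (on this read-out lower numbers stand for less inhibition and higher numbers for more inhibition at the one dose given (going by the name of the read-out)), and compound 1 `CCN(CC)C(=O)CC1CCc2cc(OC)c(OC)cc21` gives 31.5% there, with the step of a number 7.4 percentage points lower from compound 1 to compound 2 (within the scatter) sitting within the scatter, so the two compounds stand together rather than apart. Compound 3 `COc1cc2c(cc1OC)C(CC(=O)NC(C)(C)C)CC2` differs from compound 2 by tert-butyl in place of butyl on an amide-type nitrogen. Within the data shown here, the one measured step that bears on this change, a number 7.4 percentage points lower from compound 1 to compound 2 (within the scatter), was small, so the step of a number 0.9 percentage points higher from compound 2 to compound 3 (within the scatter) is expected to stay within the scatter, with no clear direction. Compound 3 is therefore estimated at 25%, with a range from 12% to 38%.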

Compound 3, a percentage reported as inhibition, in the whole organism at one dose (the size of the read-out at that dose, not a potency): 31.5%
Estimate against measurement, compound 3: 6.5 percentage points below; the measured number falls inside the stated range.
By their numbers in this assay, from the lowest: compounds 2, 1 and 3 (each within the scatter of the next).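

With tert-butyl in place of butyl on the amide-type nitrogen, the result is a number 7.4 percentage points higher from compound 2 to compound 3 (within the scatter) in this assay, so these two four-carbon groups are not told apart at this position. Set against diethylamino on the carbonyl carbon, (tert-butyl)amino gives no change at the digits printed from compound 1 to compound 3 (within the scatter), which places all three amine parts together. No measurement at hand accounts for these readings. The compounds shown leave open whether a phenyl or cyclohexyl group on this nitrogen, or a carboxylic acid in place of the amide, would stand apart from these three in this assay.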